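From piperidin-4-yl to piperidin-3-yl: a cytotoxicity estimate

The source may hold more compounds than are shown below. What is called first, only, known or untested is meant among the compounds shown, and "the series" means these compounds.

Compound 1 `Cc1nc(C(NC(=O)C(=O)Nc2ccc(Cl)cc2)C2CCNCC2)sc1CO`: 81000 nM
Compound 2 `Cc1ccc(NC(=O)C(=O)NC(c2nc(C)c(CCO)s2)C2CCCCN2)cc1F`: > 85000 nM, a limit of the assay
Compound 3 `CCn1cc(NC(=O)C(=O)Nc2ccc(Cl)cc2)cn1`: 8000 nM

All three compounds were tested in an ADME assay on TZM-b1 cells (Homo sapiens) for cytotoxicity, read by XTT assay, with a stated time of 3 days; on this read-out higher numbers stand for lower toxicity in this test and lower numbers for higher toxicity in this test. Of the two exact numbers, compound 1 stands highest at 81000 nM, while compound 3 lies lower at 8000 nM, a gap beyond the scatter. Compound 2 gives only a limit, > 85000 nM.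

Compound 4 `Cc1nc(C(NC(=O)C(=O)Nc2ccc(Cl)cc2)C2CCCNC2)sc1CO` has the same atoms as compound 1, joined differently: piperidin-3-yl in place of piperidin-4-yl on a saturated chain carbon bound to an amide-type nitrogen and an aromatic carbon. For the measured compounds named here, no measured pair shows this change, so the expectation starts from compound 1 at 81000 nM, and no step beyond the scatter is expected in this assay. The estimated change is a 1.2-fold lower number from compound 1 to compound 4 (0.06 log units; within the scatter). Compound 4 is expected at 70000 nM, with an estimated range of 30000 nM to 130000 nM.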

Compound 4, half-maximal cytotoxic concentration: 60200 nM
Beside the measured number, compound 4's estimate is 1.2-fold (0.07 log units) above it; the measured number falls inside the stated range.
By their numbers in this assay, from the lowest: compound 3; then compounds 4 and 1 (each within the scatter of the next). At a limit, above all of these: compound 2.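

In this assay, piperidin-3-yl in place of piperidin-4-yl gives a 1.3-fold lower number from compound 1 to compound 4 (0.13 log units; within the scatter), the first step shown at this saturated chain carbon bound to an amide-type nitrogen and an aromatic carbon. The two attachments of the piperidine ring thus cannot be told apart in this test. Nothing measured here bears on a cause for this step.

The compounds shown leave open whether a different group at this carbon, such as a morpholine ring or an open-chain primary amine, would give a step beyond the scatter. They also leave open whether this same change behaves alike on another core.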